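The source may hold more compounds than are shown below. What is called first, only, known or untested is meant among the compounds shown, and "the series" means these compounds.

The three compounds measured so far, with the values they gave:

Compound 1, `O=C(Nn1c(-c2cccc([N+](=O)[O-])c2)nc2c(-c3ccco3)n[nH]c2c1=O)c1cccnc1`, gives 19.2%.
Compound 2, `COc1cccc(-c2nc3c(-c4ccco4)n[nH]c3c(=O)n2NC(=O)c2cccnc2)c1`, gives 34.1%.
Compound 3, `O=C(Nn1c(-c2cccc([N+](=O)[O-])c2)nc2c(-c3cccc(Cl)c3)n[nH]c2c1=O)c1ccccc1`, gives 78.2%.

All three were read in a functional assay on SK-MEL-2 cells (Homo sapiens) for cytotoxicity, read by sulforhodamine B assay, with a stated time of 2 days, tested at 100 uM; on this read-out lower numbers stand for less inhibition and higher numbers for more inhibition at the one concentration tested (going by the name of the read-out). Compound 1 and compound 2 share a core and differ in one place, (methoxy in place of nitro on an aromatic carbon); this change made a step of a number 14.9 percentage points higher from compound 1 to compound 2 (beyond the scatter). Compound 3 stands highest of the three numbers, and its gaps to compound 2 and to compound 1 both lie beyond the usual scatter. How the core of compound 3 differs from the core of compound 1 is not broken down here.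

Compound 4, `COc1cccc(-c2nc3c(-c4cccc(Cl)c4)n[nH]c3c(=O)n2NC(=O)c2ccccc2)c1`, has not yet been measured. Among the measured compounds shown here, it differs from compound 3 by methoxy in place of nitro on an aromatic carbon, which is the same change, at a place described in the same words, as the one from compound 1 to compound 2. In this assay the step expected from compound 3 to compound 4 is therefore a number 7.8 percentage points higher from compound 3 to compound 4 (within the scatter), an expectation that rests on a number 14.9 percentage points higher from compound 1 to compound 2 (beyond the scatter). Compound 3 already stands high, and a percentage cannot rise without bound, so the expected step is set somewhat smaller than the earlier one. Compound 4 is estimated to give 86% in this assay, within a range from 66% to 98%.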

Compound 4, a percentage reported as inhibition, at one concentration (the size of the read-out at that concentration, not a potency): 81.9%
Estimate against measurement, compound 4: 4.1 percentage points above; the measured number falls inside the stated range.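

In this assay, the change from 3-nitrophenyl to 3-methoxyphenyl gave a number 3.7 percentage points higher from compound 3 to compound 4 (within the scatter). Set beside the same change on the other core, the two steps cannot be told apart: the same change on two cores in this assay, a number 14.9 percentage points higher (beyond the scatter) from compound 1 to compound 2 and a number 3.7 percentage points higher (within the scatter) from compound 3 to compound 4, 11.2 percentage points apart, within the scatter of two such steps. This shows that, across these two cores, the change gave steps of a size that the data do not separate, even though only the first step stands clear of the scatter on its own; it does not show that the step has one fixed size, since it rests on just two pairs of compounds, and it says nothing about any other core or about potency, as each number comes from a single concentration.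

The compounds shown carry only nitro and methoxy at this place on the six-membered aromatic ring, so it remains open how an amine, a carboxylic acid or a longer chain such as an ethoxy group would read there. From the compounds shown here alone, it also remains open whether the nitro-to-methoxy change would give a similar step with the group elsewhere on that ring, or in cells other than the ones used here.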